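Working notes: the amine substituent and cell cytotoxicity

The source may report more compounds than this note shows. Statements on the series, on what has been measured and on what is new or still open speak of the compounds shown alone.

Measured compounds:
compound 1 `Fc1cccc(-c2nc(Nc3ccccc3)c3cc(F)ccc3n2)c1`: 48300 nM
compound 2 `COc1ccc(Nc2nc(-c3cccc(F)c3)nc3ccc(F)cc23)cc1`: 38600 nM
compound 3 `Oc1ccc(Nc2nc(-c3cccc(F)c3)nc3ccc(F)cc23)cc1`: > 50000 nM, a limit of the assay

In a functional assay on HL-60 cells (Homo sapiens) for cytotoxicity, read by MTT assay, with a stated time of 48 h (a lower number here means a stronger inhibitor, a higher number a weaker inhibitor), compound 2 stands at 38600 nM, with compound 1 at 48300 nM; the step of a 1.3-fold lower number from compound 1 to compound 2 (0.10 log units; within the scatter) does not separate the two. Compound 3 reports only a limit in this assay (the limit of > 50000 nM in this assay, at which 1 of the 3 values shown sits). The steps of an at least 1.0-fold higher number from compound 1 to compound 3 (0.01 log units; that floor lies within the scatter) and an at least 1.2-fold higher number from compound 2 to compound 3 (0.11 log units; that floor lies within the scatter) accordingly give floors only.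

Compound 4 `Cc1ccccc1Nc1nc(-c2cccc(F)c2)nc2ccc(F)cc12` is not yet measured. It differs from compound 2 in one place: 2-methylphenyl in place of 4-methoxyphenyl on a nitrogen on an aromatic ring. The step of a 1.3-fold lower number from compound 1 to compound 2 (0.10 log units; within the scatter) bears most directly on this change: it adds the same methoxy that now leaves, and it lay within the scatter. The step of an at least 1.2-fold higher number from compound 2 to compound 3 (0.11 log units; that floor lies within the scatter) touches the same oxygen but gives only a floor. For the measured compounds named here, no measured step covers the 2-methylphenyl that enters. The expectation is therefore no step beyond the scatter in this assay, a 1.2-fold higher number from compound 2 to compound 4 (0.07 log units; within the scatter). Compound 4 is estimated at 45000 nM, with a range expected from 20000 nM to 100000 nM.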

Compound 4, half-maximal inhibitory concentration: > 50000 nM
Compound 4 ended at the assay's limit (the forecaster's own chance of this, stated with the estimate: 35%); middle value at least 1.1-fold (0.04 log units) from the limit.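

In this assay, 2-methylphenyl in place of 4-methoxyphenyl on the nitrogen gives an at least 1.2-fold higher number from compound 2 to compound 4 (0.11 log units; that floor lies within the scatter), and adding a methyl to the phenyl on that nitrogen gives an at least 1.0-fold higher number from compound 1 to compound 4 (0.01 log units; that floor lies within the scatter); both are floors only, so neither fixes the size of the change. This position has now carried phenyl, 4-methoxyphenyl, 4-hydroxyphenyl and 2-methylphenyl, and a group with no oxygen has joined the series without producing any readable step beyond the scatter. Compound 4 reports a limit of the assay, as compound 3 does, and the step between these two cannot be read: the limit of > 50000 nM in this assay, at which 2 of the 4 values shown sit.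

On these data alone, the true values of compound 3 and compound 4 remain unknown, so these floors cannot show whether either compound differs from compound 1 or compound 2 by more than the scatter. Also open are whether methyl behaves differently as 4-methylphenyl, and whether an amine or a carboxylic acid on this ring would give a number clearly separated from those shown.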